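The source may report more compounds than this note shows. Statements on the series, on what has been measured and on what is new or still open speak of the compounds shown alone.

Compound 1 `O=C1/C(=C\c2c(Cl)cccc2Cl)c2ccccc2N1c1c(Cl)cccc1Cl`; compound 2 `O=C1/C(=C\c2ccc(O)cc2)c2ccccc2N1c1c(Cl)cccc1Cl`.

In a functional assay on B16-F10 cells (Homo sapiens) for cytotoxicity against B16-F10 (Mus musculus), read by MTT assay, with a stated time of 72 h (a higher number here means that more compound is needed for the effect, a lower number that less compound is needed), compound 1 gives > 100 ug/mL, which is a limit of the assay rather than a number. In this assay compound 2 gives 33 ug/mL. Among the values shown, compound 2 holds the only true number; the other is a limit. Going by the values given here, the one measured step, an at least 3.0-fold lower number from compound 1 to compound 2 (0.48 log units; beyond the scatter), is at least modest, with its size bounded by the limit of > 100 ug/mL in this assay, at which 1 of the 2 values shown sits.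

Compound 3 `O=C1/C(=C\c2ccc(F)cc2)c2ccccc2N1c1c(Cl)cccc1Cl` differs from compound 2 by fluoro in place of hydroxy on an aromatic carbon. The measured step bears on it only loosely: it swapped the whole ring at that position, whereas this change touches one group on the ring. Only a smaller step is expected here, at most a modest rise, stated as a 1.7-fold higher number from compound 2 to compound 3 (0.22 log units; within the scatter). Compound 3 is estimated at 55 ug/mL, with a range from 20 ug/mL to 150 ug/mL.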

Compound 3, concentration for half-maximal effect: 38 ug/mL
The estimate for compound 3 lay 1.4-fold (0.16 log units) above the measured number; measured number inside the range.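

In this assay, the hydroxy group of compound 2 turns out not to be required for the lower number, as the step to fluoro is a 1.2-fold higher number from compound 2 to compound 3 (0.06 log units; within the scatter). Hydroxy, with 1 hydrogen-bond donor and 1 hydrogen-bond acceptor, and fluoro, with 0 of each, therefore cannot be told apart at this place on the ring. The gain over the 2,6-dichlorophenyl ring now appears with a second ring, 4-fluorophenyl as well as 4-hydroxyphenyl, in an at least 2.6-fold lower number from compound 1 to compound 3 (0.42 log units; beyond the scatter), and its full size is bounded by the value of compound 1, which is a limit: the limit of > 100 ug/mL in this assay, at which 1 of the 3 values shown sits.

The compounds shown leave open what an amine, a carboxylic acid or a methoxy group would give at this same place on the ring. They also leave open how a plain phenyl ring, with no added group, would compare with these rings.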